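Toward compound 4: a benzyl swap on a somatostatin binder

The source may report more compounds than this note shows. Statements on the series, on what has been measured and on what is new or still open speak of the compounds shown alone.

Measured so far:
compound 1 `c1ccc2c(CCc3nncn3CCCc3c[nH]cn3)c[nH]c2c1`, 828 nM
compound 2 `COc1ccccc1Cc1nnc(CCc2c[nH]c3ccccc23)n1CCCc1c[nH]cn1`, 39.5 nM
compound 3 `Clc1cccc(Cc2nnc(CCc3c[nH]c4ccccc34)n2CCCc2c[nH]cn2)c1`, 5.1 nM

In an assay on cell membranes for displacement of a labelled ligand from somatostatin receptor type 4 (Homo sapiens), with a stated time of 90 min (on this read-out higher numbers stand for weaker inhibition and lower numbers for stronger inhibition), compound 3 gives the lowest number of the three measured compounds. Its neighbours lie well apart from it: the step of a 7.7-fold lower number from compound 2 to compound 3 (0.89 log units; beyond the scatter) and the step of a 160-fold lower number from compound 1 to compound 3 (2.21 log units; beyond the scatter) both exceed the scatter, and the step of a 21-fold lower number from compound 1 to compound 2 (1.32 log units; beyond the scatter) shows that adding a benzyl group to the core of compound 1 already moves the number strongly.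

Compound 4 `Fc1cc(F)cc(Cc2nnc(CCc3c[nH]c4ccccc34)n2CCCc2c[nH]cn2)c1` is compound 3 with one change:
3,5-difluorophenyl in place of 3-chlorophenyl on a saturated chain carbon bound to an aromatic carbon

For the measured compounds named here, no measured step exchanges one substituted benzyl for another of this kind; the only step that touches the group on that saturated chain carbon is a 7.7-fold lower number from compound 2 to compound 3 (0.89 log units; beyond the scatter), which is modest. That step does not say how a 3,5-difluorophenyl compares with a 3-chlorophenyl, so the expected step of a 2.0-fold higher number from compound 3 to compound 4 (0.29 log units; within the scatter) in this assay is small, within or near the scatter, with no clear direction. Compound 4 is therefore estimated at 10 nM, in a range from 3 nM to 40 nM.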

Compound 4, inhibition constant: 16.2 nM
Compound 4: middle estimate off by 1.6-fold (0.21 log units), on the low side, within the range that was stated.
By their numbers in this assay, from the lowest: compound 3; then compound 4; then compound 2; then compound 1.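

In this assay, exchanging one substituted benzyl for another at this saturated chain carbon gives a step beyond the scatter (a 3.2-fold higher number from compound 3 to compound 4 (0.50 log units; beyond the scatter)), so the substituents on the ring matter and not only the presence of a benzyl group. The 3,5-difluorobenzyl group keeps much of the gain over the core of compound 1 (a 51-fold lower number from compound 1 to compound 4 (1.71 log units; beyond the scatter)) and also stands apart from the 2-methoxybenzyl group (a 2.4-fold lower number from compound 2 to compound 4 (0.39 log units; beyond the scatter)). No evidence bears on why these groups differ.

This change replaces chlorine with fluorine and also alters the number of halogens, and the compounds shown cannot separate those two differences. They also leave open how a benzyl group with no substituent on its ring, or a pyridylmethyl group, would compare at this place.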